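Nitro for Chloro at the Cytotoxicity Limit

A few compounds are considered here, and "the series" means these few. Any claim that something is new, unique, unknown or untested is made for them only; others in the source may bear on it.

In an ADME assay on L929 cells (Mus musculus) for cytotoxicity, read by resazurin assay, with a stated time of 72 h (a lower number here means a stronger inhibitor, a higher number a weaker inhibitor), compound 2 `OB1OCc2ccc(-n3cc(Sc4ccc(Cl)cc4)c4ccccc43)cc21` reaches only the limit of the measurement, > 10 ug/mL. Compound 1 `COc1ccc(Sc2cn(-c3ccc4c(c3)B(O)OC4)c3ccccc23)cc1` likewise gives a limit in this assay, > 10 ug/mL. Among the compounds with values here, the one measured step, a step that the two limits leave unreadable from compound 1 to compound 2, is unreadable because of the limit of > 10 ug/mL in this assay, at which 2 of the 2 values shown sit. Compound 3 `O=[N+]([O-])c1ccc(Sc2cn(-c3ccc4c(c3)B(O)OC4)c3ccccc23)cc1` differs from compound 2 by nitro in place of chloro on an aromatic carbon. No readable step bears on this change, so no shift beyond the scatter is expected in this assay. Compound 3 is therefore expected to sit at the limit too, with an estimated value of 15 ug/mL in a range from 7 ug/mL to 40 ug/mL. The expected step is accordingly a step that the limit leaves unreadable from compound 2 to compound 3.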

Compound 3, half-maximal inhibitory concentration: > 10 ug/mL
Compound 3 ended at the assay's limit (the forecaster's own chance of this, stated with the estimate: 80%); the middle value lies beyond the limit too.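

The steps among compound 1, compound 2 and compound 3 cannot be read, because each compound gives only a limit: the limit of > 10 ug/mL in this assay, at which 3 of the 3 values shown sit.

The compounds shown leave open whether methoxy, chloro and nitro differ at all in this assay.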